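Methoxy to fluoro: an expected flat step

This account rests on a few compounds, and the source may have more. Where it says the series, first, only, none or still open, it means among the compounds named here.

Compound 1 `Cc1ccc2c(c1)-c1cnc(n1C)OCCCCCCCCO2`: 34000 nM
Compound 2 `COc1ccc2c(c1)-c1cnc(n1C)OCCCCCCCCO2`: 34000 nM

Both values come from a functional assay on LoVo cells (Homo sapiens) for inhibition, read by colorimetric assay and MTT assay, with a stated time of 72 h (on this read-out lower numbers stand for stronger inhibition and higher numbers for weaker inhibition), and compound 2 stands level with compound 1. Compound 3 `Cn1c2cnc1OCCCCCCCCOc1ccc(F)cc1-2` is the next to be tested. It differs from compound 2 by fluoro in place of methoxy on an aromatic carbon, which means fluoro in place of methoxy on an aromatic carbon. Within the data shown here, the only measured step that bears on this is no change at the digits printed from compound 1 to compound 2 (within the scatter), with methoxy in place of methyl on an aromatic carbon. That single step is thin evidence, but it gives no reason to expect a change beyond the scatter in this assay, in either direction. The expected step is a 1.1-fold lower number from compound 2 to compound 3 (0.03 log units; within the scatter). For compound 3 the estimated value is 32000 nM, with an expected range from 15000 nM to 65000 nM.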

Compound 3, half-maximal inhibitory concentration: 43000 nM
Beside the measured number, compound 3's estimate is 1.3-fold (0.13 log units) below it; low and high end bracket the measured number.
By their numbers in this assay, from the lowest: compounds 1, 2 and 3 (each within the scatter of the next).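

At this position on the six-membered aromatic ring, there is a 1.3-fold higher number from compound 2 to compound 3 (0.10 log units; within the scatter) with fluoro in place of methoxy and a 1.3-fold higher number from compound 1 to compound 3 (0.10 log units; within the scatter) with fluoro in place of methyl. Three different groups now sit within the scatter of one another here, and even losing the hydrogen-bond acceptor counted for methoxy leaves the number within the scatter.

Still open, as far as these compounds go, is whether an amine or a carboxylic acid on this carbon would move the number beyond the scatter. No evidence in hand explains this flat result.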